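Methyl to hydrogen on the aromatic nitrogen, two cores

The source may hold more compounds than are shown below. What is called first, only, known or untested is meant among the compounds shown, and "the series" means these compounds.

Compound 3 `COc1cc(C(=O)/C(C)=C/c2cn(C)c3ccccc23)cc([Se]C)c1OC` and compound 1 `COc1cc(C(=O)/C(C)=C/c2c[nH]c3ccccc23)cc([Se]C)c1OC` share one core; compound 2 `COc1cc(C(=O)/C=C/c2cn(C)c3ccccc23)cc(N)c1OC` and compound 4 `COc1cc(C(=O)/C=C/c2c[nH]c3ccccc23)cc(N)c1OC` share another, and the difference between the two cores is not broken down here. In a functional assay on A2780 cells (Homo sapiens) for antiproliferative activity, read by MTT assay, with a stated time of 48 h (a lower number here means a stronger inhibitor, a higher number a weaker inhibitor), compound 3 gives 35 nM and compound 1 gives 25 nM; the step of a 1.4-fold lower number from compound 3 to compound 1 (0.15 log units; within the scatter) comes with the change (hydrogen in place of methyl on an aromatic nitrogen). In this assay compound 2 gives 441 nM, a far higher number than either compound 3 or compound 1, so the second core sits at a weaker level. The change hydrogen in place of methyl on an aromatic nitrogen from compound 2 to compound 4 is the same change, at the same place. Set beside the earlier step, the expected step is a 1.3-fold lower number from compound 2 to compound 4 (0.13 log units; within the scatter), resting on that single earlier step, itself within the scatter. Compound 4 is therefore estimated at 330 nM, between 150 nM and 720 nM.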

Compound 4, half-maximal inhibitory concentration: 351 nM
The estimate for compound 4 lay 1.1-fold (0.03 log units) below the measured number; the measured number falls inside the stated range.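

Hydrogen in place of methyl on the aromatic nitrogen gives a 1.3-fold lower number from compound 2 to compound 4 (0.10 log units; within the scatter) in this assay, and the two cores show no difference in this step: the same change on two cores in this assay, a 1.4-fold lower number (0.15 log units; within the scatter) from compound 3 to compound 1 and a 1.3-fold lower number (0.10 log units; within the scatter) from compound 2 to compound 4, 1.1-fold (0.05 log units) apart, within the scatter of two such steps. With both steps inside the scatter, the change has no measurable effect on either core, and its near-neutral outcome carries across this pair. This does not show that a change of real size would transfer between these cores, and two pairs say nothing about any further core.

As far as these compounds go, only methyl and hydrogen appear on the aromatic nitrogen, so an ethyl group, a longer chain or an acetyl group there remains open. From the compounds shown here alone, compound 1 and compound 4 differ in more than one place, and which part of the difference between the two cores sets their levels also remains open.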